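Swapping an aminopyridine for a carboxamide pyridine

The source may report more compounds than this note shows. Statements on the series, on what has been measured and on what is new or still open speak of the compounds shown alone.

Of the compounds shown here, two have so far been tested in a functional assay on K562 cells (Homo sapiens) for inhibition, read by MTT assay, with a stated time of 48 h; on this read-out higher numbers stand for weaker inhibition and lower numbers for stronger inhibition. Compound 1 `C[C@H](NC(=O)c1ccc(-c2ccc(N)nc2)cc1)C(=O)Nc1ccc(Cl)c(C(F)(F)F)c1` gives 5950 nM in this assay, while compound 2 `CCN(CC)C(=O)c1cncc(-c2cccc(C(=O)N[C@@H](C)C(=O)Nc3ccc(Cl)c(C(F)(F)F)c3)c2)c1` gives 29900 nM. Compound 1 therefore carries the lower of the two numbers, and its distance to compound 2 lies beyond the usual scatter of repeated measurements, so compound 1 is the stronger inhibitor of the pair.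

Compound 3 `C[C@H](NC(=O)c1ccc(-c2cncc(C(=O)NC3CC3)c2)cc1)C(=O)Nc1ccc(Cl)c(C(F)(F)F)c1` has not yet been measured. It differs from compound 1 in one place: 5-(cyclopropylcarbamoyl)pyridin-3-yl in place of 6-aminopyridin-3-yl on an aromatic carbon. For the measured compounds named here, no measured pair of compounds differs in exactly this way, so the size of such a change cannot be read off from existing results, and compound 2 offers no direct guide because its core is built differently. The step of a 1.7-fold higher number from compound 1 to compound 3 (0.23 log units; within the scatter) is expected to be modest and to run toward weaker inhibition. Compound 3 is accordingly estimated at 10000 nM, within a range from 3000 nM to 40000 nM.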

Compound 3, half-maximal inhibitory concentration: 396000 nM
The estimate for compound 3 lay 40-fold (1.60 log units) below the measured number, and the stated range ends below it.
By their numbers in this assay, from the lowest: compound 1; then compound 2; then compound 3.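

In this assay the swap of 6-aminopyridin-3-yl for 5-(cyclopropylcarbamoyl)pyridin-3-yl produces a 67-fold higher number from compound 1 to compound 3 (1.82 log units; beyond the scatter) and so shows that this place, para to a large group, is far from indifferent to the group it carries. The earlier compounds shown here could not show this, as they differ in more than one place and gave no step to read. The loss is large even though both groups count the same hydrogen-bond donors and acceptors, and nothing available explains its size.

The compounds shown leave open whether the loss follows the cyclopropyl group, the amide itself, or the different attachment of the substituent on the pyridine. A plain carboxamide or a methyl amide in place of the cyclopropyl amide would help to separate these possibilities.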